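The compounds below may be only part of what the source reports. "The series", "measured", "known", "first", "only" and "open" are said of these compounds alone.

Among the measured compounds shown here, in an ADME assay on microsomes from liver (Homo sapiens) for pharmacokinetics (a lower number here means slower removal, a higher number faster removal of the compound), compound 1 `Cc1c(Nc2nc(N)c3c(C#N)c(N4CCC[C@H]4C)n(C)c3n2)cnn1CC(C)(C)O` gives 30 mL/min/kg, the lowest of the two single numbers known so far. Compound 2 `C[C@@H]1CCCN1c1c(C#N)c2c(N)nc(Nc3cn(C)nc3Cl)nc2n1C` gives 183 mL/min/kg, a far higher number and clearly beyond the usual scatter. Compound 3 `Cc1nn(C2CCOC2)cc1Nc1nc(N)c2c(C#N)c(N3CCC[C@H]3C)n(C)c2n1` gives 76.7 mL/min/kg; 200 mL/min/kg (2 entries) across its repeated entries. The untested compound 4 `Cc1c(Nc2nc(N)c3c(C#N)c(N4CCC[C@H]4C)n(C)c3n2)cnn1[C@H]1CCOC1` differs from compound 1 in one place: oxolan-3-yl in place of 2-hydroxy-2-methylpropyl on an aromatic nitrogen Compound 3 already carries an oxolan-3-yl group on that aromatic nitrogen, and its repeated entries the several entries of compound 3 in this assay, 76.7 mL/min/kg; 200 mL/min/kg (2 entries) both lie well above the number for compound 1. Faster removal is therefore expected, by a step estimated as a 3.7-fold higher number from compound 1 to compound 4 (0.56 log units; beyond the scatter). For compound 4 the expected value is 110 mL/min/kg, with a likely range from 45 mL/min/kg to 220 mL/min/kg.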

Compound 4, clearance: 23.3 mL/min/kg
Compound 4: middle estimate off by 4.7-fold (0.67 log units), on the high side; the whole stated range lies above it.
By their numbers in this assay, from the lowest: compounds 4 and 1 (each within the scatter of the next); then compound 2.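

In this assay, swapping 2-hydroxy-2-methylpropyl, with its hydrogen-bond donor, for the ring of oxolan-3-yl gives a 1.3-fold lower number from compound 1 to compound 4 (0.11 log units; within the scatter), so the two groups cannot be told apart here and a low number at this position does not need that donor. An oxolan-3-yl group on an aromatic nitrogen therefore does not by itself go with the high numbers of compound 3, whose ring is substituted differently: the several entries of compound 3 in this assay, 76.7 mL/min/kg; 200 mL/min/kg (2 entries)

Open, going by these compounds, is whether an amine or a carboxylic acid on this nitrogen would keep the number as low. Also open, on these data alone, is how the other stereoisomer of oxolan-3-yl would behave.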